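Methoxy in Place of Methyl: Solubility Expected Unchanged

The source may hold more compounds than are shown below. What is called first, only, known or untested is meant among the compounds shown, and "the series" means these compounds.

Compound 1 `Cc1ccc2c(c1)[n+]([O-])c(NCCN(C)C)n[n+]2[O-]` gives, in a physicochemical assay for solubility, in the presence of a further agent that is not named here (a higher number here means a more soluble compound, a lower number a less soluble compound), a value that is a limit of the assay, > 51000000 nM. Compound 2 `Cc1ccc2c(c1)[n+]([O-])c(NCCN1CCCCC1)n[n+]2[O-]` gives 45000000 nM. Compound 3 `CCCN(CCC)CCNc1n[n+]([O-])c2ccc(C)cc2[n+]1[O-]` gives 38000000 nM.

Among the two numbers, compound 2 stands highest, with compound 3 nearest a 1.2-fold lower number from compound 2 to compound 3 (0.07 log units; within the scatter). Compound 4 `COc1ccc2c(c1)[n+]([O-])c(NCCN1CCCCC1)n[n+]2[O-]` differs from compound 2 by methoxy in place of methyl on an aromatic carbon. Every measured step alters only the amine on the chain: an at least 1.1-fold lower number from compound 1 to compound 2 (0.05 log units; that floor lies within the scatter), an at least 1.3-fold lower number from compound 1 to compound 3 (0.12 log units; that floor lies within the scatter), a 1.2-fold lower number from compound 2 to compound 3 (0.07 log units; within the scatter). Going by the values given here, none touches the methyl on the aromatic ring, so no measured step bears directly on this change, and all of them lie within the scatter. Compound 4 is therefore expected to show no step beyond the scatter, no change at the digits printed from compound 2 to compound 4 (within the scatter), with an estimated value of 45000000 nM, between 20000000 nM and 90000000 nM.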

Compound 4, solubility: 45000000 nM
Compound 4: the middle estimate sits on the measured number at the digits printed; the measured number falls inside the stated range.
By their numbers in this assay, from the lowest: compounds 3, 2 and 4 (each within the scatter of the next). At a limit, above all of these: compound 1.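

Compound 4 gives the only reading shown of a change on the aromatic ring rather than on the chain amine: in this assay, methoxy in place of methyl on an aromatic carbon brings no change at the digits printed from compound 2 to compound 4 (within the scatter) on the shared core. With the piperidin-1-yl chain held fixed, this position takes the added oxygen without a step beyond the scatter. Any room for a rise is bounded by a limit of the assay: the limit of > 51000000 nM in this assay, at which 1 of the 4 values shown sits.

On these data alone, whether this holds with the dimethylamino or dipropylamino chains stays open, as does what a chlorine, an amine or a carboxylic acid on this aromatic carbon would give.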